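The compounds below may be only part of what the source reports. "The series", "measured", "known", "first", "only" and "open" are said of these compounds alone.

The three measured compounds share one core and differ at a single aromatic carbon and its substituent. Compound 1 `C[C@@H](Oc1cc2oc(=O)n(CCC(=O)O)c2cc1Cl)c1ccc(Cl)cn1` gives 2.65 in a physicochemical assay for lipophilicity, read by HPLC, at pH 7.4; a higher number here means a more lipophilic compound, a lower number a more polar compound. Compound 2 `C[C@@H](Oc1cc2oc(=O)n(CCC(=O)O)c2cc1Cl)c1ccc(F)cn1` gives 1.98, and compound 3 `CCOc1cc2oc(=O)n(CCC(=O)O)c2cc1Cl` gives 1.49. Compound 3 thus stands lowest of the three, with compound 2 nearest to it and compound 1 furthest. The measured steps show a number 0.67 log units lower from compound 1 to compound 2 (beyond the scatter), a number 1.16 log units lower from compound 1 to compound 3 (beyond the scatter) and a number 0.49 log units lower from compound 2 to compound 3 (beyond the scatter).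

Compound 4 `O=C(O)CCn1c(=O)oc2cc(Cl)c(Cl)cc21` is not yet measured. It differs from compound 3 by chloro in place of ethoxy on an aromatic carbon. Among the measured compounds shown here, none of the measured steps exchanges one group for another at this position; the step from compound 1 to compound 2 is the only one that touches a chloro group, and it shows how much the swap of one halogen for another moves the number. That step bears only loosely on the present change, since here the chloro group replaces an ethoxy group rather than a fluoro group. The expectation is therefore a modest rise rather than a fall, with the step of a number 0.31 log units higher from compound 3 to compound 4 (beyond the scatter) expected in this assay. Compound 4 is estimated at 1.8, within a range from 1.4 to 2.2.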

Compound 4, distribution coefficient: 1.61
Compound 4: middle estimate off by 0.19 log units, on the high side; the measured number falls inside the stated range.
By their numbers in this assay, from the lowest: compounds 3 and 4 (each within the scatter of the next); then compound 2; then compound 1.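

In this assay, putting chloro in place of ethoxy on this aromatic carbon, ortho to a chloro group, gives a number 0.12 log units higher from compound 3 to compound 4 (within the scatter) and so leaves the two compounds indistinguishable, even though a group of 3 heavy atoms with 1 hydrogen-bond acceptor gives way to a single chlorine. The earlier steps shown here at this position, such as a number 0.49 log units lower from compound 2 to compound 3 (beyond the scatter) and a number 1.16 log units lower from compound 1 to compound 3 (beyond the scatter), all kept the oxygen on the aromatic carbon and changed only what it carried, whereas this one removes that oxygen and still produces no change beyond the scatter, so the oxygen-for-chlorine exchange itself, in this one pair, is not seen to shift the reading. Nothing shown here offers a measured reason why the two groups read alike.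

The compounds shown leave open how other groups on this carbon, such as an amine, a nitrile or a longer alkoxy chain, would read in this assay. They also leave open whether chloro and ethoxy would still read alike if the chain carrying the carboxylic acid were longer or the neighbouring chloro group were replaced.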